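Dropping the Bromo Group: What One Step Can Suggest

The source may report more compounds than this note shows. Statements on the series, on what has been measured and on what is new or still open speak of the compounds shown alone.

Measured so far:
Compound 1, `COc1cc(-c2cc(-c3ccc(N)cc3)nc(-c3ccccc3)n2)cc(OC)c1OC`, in a functional assay on HT-29 cells (Homo sapiens) for inhibition, read by MTT assay, with a stated time of 48 h (a higher number here means a weaker inhibitor, a lower number a stronger inhibitor), gives a limit of > 25000 nM.
Compound 2, `COc1cc(-c2cc(-c3ccc(Br)cc3)nc(-c3ccccc3)n2)cc(OC)c1OC`, in this assay gives 3170 nM.

Among the measured compounds shown here, compound 2 thus holds the only true number; the value of compound 1 is a limit of this assay, not a number. For the measured compounds named here, the single measured step, an at least 7.8-fold lower number from compound 1 to compound 2 (0.89 log units; beyond the scatter), lies beyond the scatter. Compound 3, `COc1cc(-c2cc(-c3ccccc3)nc(-c3ccccc3)n2)cc(OC)c1OC`, differs from compound 2 by hydrogen in place of bromo on an aromatic carbon. Going by the values given here, no measured step covers bromo to hydrogen directly, so the expected change is uncertain; compound 3 is expected to show a 1.9-fold higher number from compound 2 to compound 3 (0.28 log units; within the scatter). Compound 3 is estimated at 6000 nM, between 2000 nM and 20000 nM.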

Compound 3, half-maximal inhibitory concentration: 7930 nM
For compound 3 the middle estimate is 1.3-fold (0.12 log units) below the measured one; the measured number falls inside the stated range.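

Going from the 4-bromophenyl to phenyl gives a real if modest change in this assay, with a 2.5-fold higher number from compound 2 to compound 3 (0.40 log units; beyond the scatter), so the bromo group counts for something at this position. Hydrogen in the same place also compares well with amino, with an at least 3.1-fold lower number from compound 1 to compound 3 (0.49 log units; beyond the scatter), and the order here runs bromo, hydrogen, amino. Compound 1 stands at a limit and not a number, so that second step is only a bound: the limit of > 25000 nM in this assay, at which 1 of the 3 values shown sits.

On these data alone, whether chloro, methoxy or a carboxylic acid in this place would fit that order stays open.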